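Swapping the ethoxyphenyl for a dimethylphenyl: an estimate

The source may hold more compounds than are shown below. What is called first, only, known or untested is meant among the compounds shown, and "the series" means these compounds.

Compound 1 `CCc1ccccc1-n1nncc1CN1C(=O)C2(C(C#N)=C(N)Oc3c(N)cc4nc5ccccc5nc4c32)c2ccccc21`: in a functional assay on HCT-116 cells (Homo sapiens) for antiproliferative activity, read by MTT assay, with a stated time of 48 h (a lower number here means a stronger inhibitor, a higher number a weaker inhibitor), compound 1 gives 10300 nM.
Compound 2 `CCOc1ccccc1-n1nncc1CN1C(=O)C2(C(C#N)=C(N)Oc3c(N)cc4nc5ccccc5nc4c32)c2ccccc21`: in this assay compound 2 reaches only a limit of the assay, > 50000 nM.

Compound 2 thus stands at the weak end of the two measured compounds; its value is not a number but the point beyond which the assay no longer resolves, as shown by the limit of > 50000 nM in this assay, at which 1 of the 2 values shown sits. Among the measured compounds shown here, the only measured step, an at least 4.8-fold higher number from compound 1 to compound 2 (0.68 log units; beyond the scatter), replaced an ethyl with an ethoxy on the aromatic carbon and lost at least modest activity.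

Compound 3 `Cc1cc(C)cc(-n2nncc2CN2C(=O)C3(C(C#N)=C(N)Oc4c(N)cc5nc6ccccc6nc5c43)c3ccccc32)c1` differs from compound 2 by 3,5-dimethylphenyl in place of 2-ethoxyphenyl on an aromatic nitrogen. This removes the ethoxy that accompanied the loss in an at least 4.8-fold higher number from compound 1 to compound 2 (0.68 log units; beyond the scatter) and returns to a phenyl that carries only alkyl groups, as in compound 1. Compound 3 is therefore expected to recover activity, with a step of an at least 3.3-fold lower number from compound 2 to compound 3 (0.52 log units; beyond the scatter) in this assay toward stronger inhibition. Compound 3 is estimated at 15000 nM, within a range from 4000 nM to 60000 nM, with a real chance that the assay again reports only a limit.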

Compound 3, half-maximal inhibitory concentration: > 50000 nM
Compound 3 gave a limit, no number (the forecaster's own chance of this, stated with the estimate: 30%); middle value at least 3.3-fold (0.52 log units) from the limit.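

The ethoxy oxygen cannot be the whole story at this position: the 3,5-dimethylphenyl on the aromatic nitrogen also carries only alkyl groups, like the 2-ethylphenyl, yet this assay shows an at least 4.8-fold higher number from compound 1 to compound 3 (0.68 log units; beyond the scatter). An all-carbon substituted phenyl is therefore not enough to keep the measurable activity, and of the three groups shown, only the 2-ethylphenyl of compound 1 gives an actual number, 10300 nM. The change from 2-ethoxyphenyl to 3,5-dimethylphenyl cannot be ranked, and its step cannot be read, because compound 2 and compound 3 both give limits rather than numbers: the limit of > 50000 nM in this assay, at which 2 of the 3 values shown sit.

The compounds shown do not separate the identity of the substituents from where they sit on the phenyl, for compound 3 differs from compound 1 in both the number and the placement of its alkyl groups. On these data alone, how an unsubstituted phenyl, a 2-methylphenyl or a phenyl bearing an amine would behave in this assay remains open, and any of these could help show whether the 2-ethylphenyl result is specific to that group.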